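The source may hold more compounds than are shown below. What is called first, only, known or untested is meant among the compounds shown, and "the series" means these compounds.

Measured so far in a functional assay on PC-3 cells (Homo sapiens) for cytotoxicity, read by MTT assay, with a stated time of 48 h; on this read-out higher numbers stand for weaker inhibition and lower numbers for stronger inhibition:
compound 1 `COc1cc(-c2nnc3n2NC(c2ccco2)C(C(=O)c2ccc(F)cc2)S3)cc(OC)c1OC` gives 27700 nM
compound 2 `COc1cc(-c2nnc3n2NC(c2ccco2)C(C(=O)c2ccc(C)cc2)S3)cc(OC)c1OC` gives 7500 nM
compound 3 `COc1cc(-c2nnc3n2NC(c2ccco2)C(C(=O)c2ccc(C(F)(F)F)cc2)S3)cc(OC)c1OC` gives 77500 nM

Compound 3 stands at the top of these three numbers, meaning the weakest inhibition: the step of a 2.8-fold higher number from compound 1 to compound 3 (0.45 log units; beyond the scatter) was modest, and the step of a 10-fold higher number from compound 2 to compound 3 (1.01 log units; beyond the scatter) was large. The third comparison, a 3.7-fold lower number from compound 1 to compound 2 (0.57 log units; beyond the scatter), shows that the group on the aromatic ring attached to the carbonyl moves the number in both directions.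

Compound 4 `COc1cccc(C(=O)C2Sc3nnc(-c4cc(OC)c(OC)c(OC)c4)n3NC2c2ccco2)c1` has not yet been measured. It differs from compound 3 in one place: 3-methoxyphenyl in place of 4-(trifluoromethyl)phenyl on a carbonyl carbon. All three measured steps change a group on that same ring, but none of them brings in a methoxy or takes the trifluoromethyl away entirely, so they are only a loose guide. Because compound 3 gave 77500 nM, the highest number of the set, and both other ring groups gave lower numbers, a lower number is expected for compound 4. The expected step is a 5.2-fold lower number from compound 3 to compound 4 (0.71 log units; beyond the scatter). Compound 4 is estimated at 15000 nM, with a range from 4000 nM to 60000 nM.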

Compound 4, half-maximal inhibitory concentration: 84600 nM
Estimate against measurement, compound 4: 5.6-fold (0.75 log units) below; measured number outside the range, above it.
By their numbers in this assay, from the lowest: compound 2; then compound 1; then compounds 3 and 4 (each within the scatter of the next).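

In this assay, exchanging 4-(trifluoromethyl)phenyl for 3-methoxyphenyl on the carbonyl carbon gives a 1.1-fold higher number from compound 3 to compound 4 (0.04 log units; within the scatter) and so leaves the number unmoved, even though both the group and its place on the ring differ. The same ring sets compound 4 clearly apart from the other two compounds, with an 11-fold higher number from compound 2 to compound 4 (1.05 log units; beyond the scatter) and a 3.1-fold higher number from compound 1 to compound 4 (0.48 log units; beyond the scatter), so 4-methylphenyl in compound 2 still gives the lowest number of the four, and this position separates these rings rather than following one simple order. No supporting measurement offers an explanation for these numbers.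

With a methoxy group seen only in the 3-methoxyphenyl ring, the compounds shown cannot separate the effect of the methoxy group from that of its place on the ring. On these data alone, how an amine or a carboxylic acid on this ring would read also remains open.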